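Threonine-type side chain on a terpenoid quinone aminoacid

The compounds below may be only part of what the source reports. "The series", "measured", "known", "first", "only" and "open" are said of these compounds alone.

Measured compounds:
Compound 1 `C=C1[C@H](C)CCC[C@]1(C)CC/C(C)=C/CC1=C(O)C(=O)C=C(N[C@@H](CO)C(=O)O)C1=O` — in an ADME assay on L1210 cells (Mus musculus) for cytotoxicity, with a stated time of 48 h (on this read-out higher numbers stand for weaker inhibition and lower numbers for stronger inhibition), compound 1 gives > 10 ug/mL, a limit of the assay.
Compound 2 `C=C1[C@H](C)CCC[C@]1(C)CC/C(C)=C/CC1=C(O)C(=O)C=C(N[C@@H](C(=O)O)C(C)C)C1=O` — in this assay compound 2 gives 3.4 ug/mL.
Compound 3 `COC1=CC(=O)C(O)=C(C/C=C(\C)CC[C@@]2(C)CCC=C(C)[C@H]2C)C1=O` — in this assay compound 3 gives 2 ug/mL.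

Compound 2 and compound 3 give numbers within the scatter of each other, so no order can be read between them. Compound 1 sits at the limit of > 10 ug/mL in this assay, at which 1 of the 3 values shown sits, and supplies no number.

Compound 4 `C=C1[C@H](C)CCC[C@]1(C)CC/C(C)=C/CC1=C(O)C(=O)C=C(N[C@H](C(=O)O)[C@H](C)O)C1=O` is unmeasured. It differs from compound 2 in one place (1-carboxy-2-hydroxypropyl in place of 1-carboxy-2-methylpropyl on an amine nitrogen).

Going by the values given here, one measured step bears on this change: an at least 2.9-fold lower number from compound 1 to compound 2 (0.46 log units; beyond the scatter), which ran from 1-carboxy-2-hydroxyethyl to 1-carboxy-2-methylpropyl on the same amine nitrogen. The present step runs the other way in kind, with a hydroxyl returning on the side chain, so a higher number is expected for compound 4 in this assay, of a size near that step and possibly reaching the limit again. Compound 4 is therefore estimated at 8 ug/mL, range 3.5 ug/mL to 20 ug/mL, an expected step of a 2.4-fold higher number from compound 2 to compound 4 (0.37 log units; beyond the scatter).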

Compound 4, half-maximal inhibitory concentration: > 10 ug/mL
Compound 4 ended at the assay's limit; the forecaster's own chance of this, stated with the estimate: 40%; at least 1.2-fold (0.09 log units) between middle value and limit.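

In this assay, placing 1-carboxy-2-hydroxypropyl for 1-carboxy-2-methylpropyl on the amine nitrogen gives an at least 2.9-fold higher number from compound 2 to compound 4 (0.46 log units; beyond the scatter), so the change first seen in an at least 2.9-fold lower number from compound 1 to compound 2 (0.46 log units; beyond the scatter) now also appears from the other direction. This new step keeps the heavy-atom count of the group and exchanges one carbon for oxygen, so a sharp loss follows even without a change in group size. Both compounds with a hydroxyl on this side chain now stand at a limit, not at a number, and the step between them cannot be read: the limit of > 10 ug/mL in this assay, at which 2 of the 4 values shown sit.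

As far as these compounds go, how far compound 1 and compound 4 lie past that limit remains unknown. The compounds shown also leave open how a methoxy group, an amine or a second carboxylic acid on this side chain would read out, or whether a longer carbon chain would go beyond compound 2.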